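Adding bromo to a compound at the assay limit

A few compounds are considered here, and "the series" means these few. Any claim that something is new, unique, unknown or untested is made for them only; others in the source may bear on it.

Compound 1 (`O=c1nc2ccc(Br)cn2cc1Cc1ccc(Br)cc1`) gives > 1000000 nM as a limit
Compound 2 (`O=c1nc2ccccn2cc1Cc1ccc(F)cc1`) gives > 1000000 nM as a limit
Compound 3 (`O=c1nc2ccccn2cc1Cc1ccccc1`) gives > 1000000 nM as a limit

In a functional assay on HepG2 cells (Homo sapiens) for cytotoxicity, read by MTT assay, with a stated time of 24 h (a higher number here means a weaker inhibitor, a lower number a stronger inhibitor), compound 3 has no exact number, only the limit > 1000000 nM as its reading. The other two compounds stand the same way, so the whole set rests on the limit of > 1000000 nM in this assay, at which 3 of the 3 values shown sit, and on no exact value.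

Compound 4 (`O=c1nc2ccccn2cc1Cc1ccc(Br)cc1`) differs from compound 3 in one place, with bromo in place of hydrogen on an aromatic carbon of a six-membered aromatic ring of carbon only, para to a large group.

Among the measured compounds shown here, the only measured step between two close compounds is a step that the two limits leave unreadable from compound 2 to compound 3 for hydrogen in place of fluoro on an aromatic carbon. It offers no size to carry over, and the numbers point in neither direction. No step beyond the scatter is therefore expected in this assay and compound 4 will most likely report only a limit too. The expected step is a number no higher from compound 3 to compound 4 (the limit leaves the size open) as an estimate and no more. For compound 4 the estimated value is 1000000 nM with an expected range from 400000 nM to 2000000 nM in this read-out.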

Compound 4, half-maximal inhibitory concentration: > 1000000 nM
Compound 4: only a limit was reported; the forecaster's own chance of this, stated with the estimate: 90%; the middle value lies on the limit itself.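

In this assay compound 4 gives > 1000000 nM, which is a limit and not a number. Among the compounds shown here, no step between compound 4 and compound 1, compound 2 or compound 3 can be read, because all four share one reading: the limit of > 1000000 nM in this assay, at which 4 of the 4 values shown sit. The compounds shown leave open whether exchanging hydrogen, fluoro and bromo changes the cytotoxicity at all.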